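Permeability of compound 4 with a dioxanyl group

The source may report more compounds than this note shows. Statements on the series, on what has been measured and on what is new or still open speak of the compounds shown alone.

Compound 1 `NC(=O)[C@@H](CCC(F)(F)F)N(CC1COC1)S(=O)(=O)c1ccc(Cl)cc1` carries an oxetan-3-yl ring on a saturated chain carbon bound to a sulfonamide nitrogen. Within the data shown here, in an ADME assay on MDCKII-LE cells (Canis lupus familiaris) for permeability, read by transwell migration, in the apical to basolateral direction (a higher number here means that the compound crosses the layer faster, a lower number that the compound crosses the layer more slowly), compound 1 gives 25.4 10^-6 cm/s, which is the second highest of the three numbers measured so far, all of them within the scatter of one another. Compound 2 `NC(=O)[C@@H](CCC(F)(F)F)N(C[C@H]1CCCCO1)S(=O)(=O)c1ccc(Cl)cc1` gives 13.4 10^-6 cm/s, and compound 3 `NC(=O)[C@@H](CCC(F)(F)F)N(CC1CCOCC1)S(=O)(=O)c1ccc(Cl)cc1` gives 26.3 10^-6 cm/s.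

Compound 4 `NC(=O)[C@@H](CCC(F)(F)F)N(C[C@@H]1COCCO1)S(=O)(=O)c1ccc(Cl)cc1` differs from compound 1 in one place: 1,4-dioxan-2-yl in place of oxetan-3-yl on a saturated chain carbon bound to a sulfonamide nitrogen

Among the measured compounds shown here, two measured steps bear on this change. Going from the oxetan-3-yl of compound 1 to oxan-2-yl, a 1.9-fold lower number from compound 1 to compound 2 (0.28 log units; within the scatter), and going to oxan-4-yl, a 1.0-fold higher number from compound 1 to compound 3 (0.02 log units; within the scatter). Both replacements leave the number within the scatter, so no step beyond the scatter is expected for compound 4 either, with at most a slight drift downward as seen from compound 1 to compound 2, a 1.9-fold lower number from compound 1 to compound 2 (0.28 log units; within the scatter).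

Compound 4 is therefore estimated to give 18 10^-6 cm/s, with a range from 9 10^-6 cm/s to 36 10^-6 cm/s; this means an expected step of a 1.4-fold lower number from compound 1 to compound 4 (0.15 log units; within the scatter).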

Compound 4, apparent permeability: 27.3 10^-6 cm/s
Beside the measured number, compound 4's estimate is 1.5-fold (0.18 log units) below it; the range from low to high includes it.
By their numbers in this assay, from the lowest: compounds 2, 1, 3 and 4 (each within the scatter of the next, the first and the last beyond it).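

In this assay the 1,4-dioxan-2-yl ring joins the oxetan-3-yl and oxan-4-yl rings on this saturated chain carbon bound to a sulfonamide nitrogen, with a 1.1-fold higher number from compound 1 to compound 4 (0.03 log units; within the scatter) and a 1.0-fold higher number from compound 3 to compound 4 (0.02 log units; within the scatter) as the steps, so a larger ring with a second ring oxygen brings no step beyond the scatter among these three compounds. Among these compounds, the change also gives the first step beyond the scatter at this place, a 2.0-fold higher number from compound 2 to compound 4 (0.31 log units; beyond the scatter) and modest in size, which sets the oxan-2-yl of compound 2 apart from compound 4 only, and not from compound 1 or compound 3. No measurement at hand accounts for that gap.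

Every compound shown carries a cyclic ether at this place. From the compounds shown here alone, how a cyclohexyl ring with no oxygen, or a piperidin-4-yl ring with an amine nitrogen, would read here stays open.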